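Acetyl in Place of Nitro on the Sulfonate Aryl Ring

A few compounds are considered here, and "the series" means these few. Any claim that something is new, unique, unknown or untested is made for them only; others in the source may bear on it.

Compound 1 `CNC(=O)/C=C1/COc2cc(OS(=O)(=O)c3ccc(Cl)cc3)ccc21`: 12 nM
Compound 2 `CNC(=O)/C=C1/COc2cc(OS(=O)(=O)c3ccc([N+](=O)[O-])cc3)ccc21`: 37 nM

In an assay (strain Sprague-Dawley) for inhibition of Amine oxidase [flavin-containing] A (Rattus norvegicus), read by spectrophotometry, with a stated time of 5 min (a lower number here means a stronger inhibitor, a higher number a weaker inhibitor), compound 2 gives the higher of the two numbers; compound 1, the nearest, sits at 12 nM, the step of a 3.1-fold higher number from compound 1 to compound 2 (0.49 log units; beyond the scatter) lying beyond the scatter. Compound 3 `CNC(=O)/C=C1/COc2cc(OS(=O)(=O)c3ccc(C(C)=O)cc3)ccc21` differs from compound 2 by acetyl in place of nitro on an aromatic carbon. Going by the values given here, only one measured step, nitro for chloro, bears on this change, and it was modest, so compound 3 is expected to land near compound 2, estimated as a 1.2-fold lower number from compound 2 to compound 3 (0.09 log units; within the scatter). Compound 3 is estimated at 30 nM, ranging from 10 nM to 90 nM.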

Compound 3, half-maximal inhibitory concentration: 29 nM
Beside the measured number, compound 3's estimate is 1.0-fold (0.01 log units) above it, and the stated range covers the measured number.
By their numbers in this assay, from the lowest: compound 1; then compounds 3 and 2 (each within the scatter of the next).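

At this position on the aromatic ring, acetyl and nitro cannot be told apart in this assay (a 1.3-fold lower number from compound 2 to compound 3 (0.11 log units; within the scatter)). Acetyl in place of chloro (a 2.4-fold higher number from compound 1 to compound 3 (0.38 log units; beyond the scatter)) shows that compound 1, with chloro, stays beyond the scatter from both other compounds, so its gap to compound 2 is not unique to nitro. No evidence is available to explain these results.

From the compounds shown here alone, what remains open is whether an amine, a carboxylic acid or a methoxy group here would fall with chloro or with acetyl and nitro. Also open, going by these compounds, is whether a longer chain in place of acetyl would keep the same reading.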